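The source may hold more compounds than are shown below. What is called first, only, known or untested is meant among the compounds shown, and "the series" means these compounds.

Measured so far:

Compound 1 `C=CC[N+](C)(C)c1cccc(OC)c1` — in a functional assay with Cavia porcellus as the target (on this read-out higher numbers stand for weaker inhibition and lower numbers for stronger inhibition), compound 1 gives only a limit of the assay, > 3000 nM.
Compound 2 `C=CC[N+](C)(C)c1cccc(OC(C)=O)c1` — in this assay compound 2 gives 3870 nM.
Compound 3 `COc1ccccc1[N+](C)(C)Cc1ccccc1` — in this assay compound 3 gives only a limit of the assay, > 3000 nM.

For the measured compounds named here, the one change that has been measured is acetyl in place of methyl on an oxygen on an aromatic ring. Its step, a step that the limit leaves unreadable from compound 1 to compound 2, cannot be sized because the limit of > 3000 nM in this assay, at which 2 of the 3 values shown sit, hides where compound 1 truly stands; all that is known is that compound 2 gives a number close to that limit.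

Compound 4 `CC(=O)Oc1ccccc1[N+](C)(C)Cc1ccccc1` is not yet measured. It is built on the core of compound 3, and the difference between the core of compound 1 and the core of compound 3 is not broken down here. The change from compound 3 to compound 4 is acetyl in place of methyl on an oxygen on an aromatic ring, the same change as before, at a place described in the same words.

In this assay the step expected from compound 3 to compound 4 is a step that the limit leaves unreadable from compound 3 to compound 4. Going by the values given here, this expectation rests on the only comparable step, a step that the limit leaves unreadable from compound 1 to compound 2, which is itself unreadable, and on compound 3 sitting at the same limit, (the limit of > 3000 nM in this assay, at which 2 of the 3 values shown sit), so the expectation is loose.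

Compound 4 is estimated at 4000 nM, expected to fall between 1500 nM and 12000 nM.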

Compound 4, half-maximal inhibitory concentration: > 3000 nM
Compound 4: a limit, no number; the forecaster's own chance of this, stated with the estimate: 50%; the middle value is on the limit's open side.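

In this assay compound 4 gives only a limit of the assay, > 3000 nM. For the compounds shown here, compound 3 also stands at a limit, so no step from compound 3 to compound 4 can be read, because neither compound has a number: the limit of > 3000 nM in this assay, at which 3 of the 4 values shown sit. The compounds shown leave open whether acetyl in place of methyl on an oxygen on an aromatic ring changes inhibition in this assay on either core.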